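Adding a third methoxy group to compound 3

This account rests on a few compounds, and the source may have more. Where it says the series, first, only, none or still open, it means among the compounds named here.

Measured in a functional assay on HGC-27 cells (Homo sapiens) for cytotoxicity, read by MTT assay, with a stated time of 48 h (a higher number here means a weaker inhibitor, a lower number a stronger inhibitor), as follows
Compound 1 (`COc1ccc(/C=C/C(=O)/C=C/c2cc3ccccc3nc2Oc2cccc(Cl)c2)c(OC)c1`) gives > 10000 nM as a limit
Compound 2 (`COc1ccc(OC)c(/C=C/C(=O)/C=C/c2cc3ccccc3nc2Oc2cccc(Cl)c2)c1`) gives > 10000 nM as a limit
Compound 3 (`COc1ccc(/C=C/C(=O)/C=C/c2cc3ccccc3nc2Oc2cccc(Cl)c2)cc1OC`) gives > 10000 nM as a limit

Each of these entries is a limit of the assay and not a number. Compound 3 therefore has no exact place on the scale, and the whole series looks the same, with the limit of > 10000 nM in this assay, at which 3 of the 3 values shown sit, as its only landmark.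

Compound 4 (`COc1cc(OC)c(OC)cc1/C=C/C(=O)/C=C/c1cc2ccccc2nc1Oc1cccc(Cl)c1`) carries one change relative to compound 3 (methoxy in place of hydrogen on an aromatic carbon) which turns 3,4-dimethoxyphenyl into 2,4,5-trimethoxyphenyl.

Within the data shown here, the steps that bear on this change move the two methoxy groups around the same ring. Here a step that the two limits leave unreadable from compound 1 to compound 2 and a step that the two limits leave unreadable from compound 1 to compound 3 and a step that the two limits leave unreadable from compound 2 to compound 3 give no size and no direction. None of them adds a methoxy group, so no step beyond the scatter is expected in this assay on this evidence.

The estimated move is a step that the limit leaves unreadable from compound 3 to compound 4 and it is only an expectation. A further limit rather than a number is the most likely report for compound 4. For compound 4 the estimate is 12000 nM with an expected range from 3000 nM to 40000 nM as its span.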

Compound 4, half-maximal inhibitory concentration: > 10000 nM
Compound 4 was reported as a limit; the forecaster's own chance of this, stated with the estimate: 70%; the middle value does not contradict the limit.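

Compound 4 is reported as a limit and not a number, like compound 1, compound 2 and compound 3, so none of its steps to them can be read in this assay, and one landmark remains: the limit of > 10000 nM in this assay, at which 4 of the 4 values shown sit.

The compounds shown leave open how strong any of the four is, and whether turning 3,4-dimethoxyphenyl into 2,4,5-trimethoxyphenyl changes that strength at all.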